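A ring swap on compound 2

The source may hold more compounds than are shown below. What is called first, only, known or untested is meant among the compounds shown, and "the series" means these compounds.

Compound 2 `CN1CCN(c2cc(C(F)(F)F)ccc2[C@H]2CCOc3cc(S(=O)(=O)Nc4nccs4)ccc32)CC1` gives 176000 nM in a physicochemical assay for solubility (a higher number here means a more soluble compound, a lower number a less soluble compound), and so lies within the scatter of compound 3 `Cc1nc(-c2cc(C(F)(F)F)ccc2[C@@H]2CCOc3cc(S(=O)(=O)Nc4nccs4)ccc32)co1` at 130000 nM and clearly lower than compound 1 `O=S(=O)(Nc1ncccn1)c1ccc2c(c1)OCC[C@@H]2c1ccc(C(F)(F)F)cc1-c1ccc(F)nc1` at 408000 nM in the same test. Compound 4 `Cn1nccc1-c1cc(C(F)(F)F)ccc1[C@H]1CCOc2cc(S(=O)(=O)Nc3nccs3)ccc21` replaces 4-methylpiperazin-1-yl with 1-methyl-1H-pyrazol-5-yl on an aromatic carbon (1-methyl-1H-pyrazol-5-yl in place of 4-methylpiperazin-1-yl on an aromatic carbon). For the measured compounds named here, no measured pair isolates this change, so the closest guide is compound 3, which also carries a five-membered aromatic ring there and gives 130000 nM in this assay as well. A small fall is therefore expected, with a 1.4-fold lower number from compound 2 to compound 4 (0.13 log units; within the scatter) as the estimated step, not beyond the scatter. Compound 4 is estimated at 130000 nM with a range from 55000 nM to 280000 nM expected.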

Compound 4, solubility: 83000 nM
Beside the measured number, compound 4's estimate is 1.6-fold (0.19 log units) above it, within the range that was stated.
By their numbers in this assay, from the lowest: compounds 4, 3 and 2 (each within the scatter of the next, the first and the last beyond it); then compound 1.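

For the compounds shown here, on an aromatic carbon meta to a trifluoromethyl group, this is the first one-place comparison: in this assay, 1-methyl-1H-pyrazol-5-yl in place of 4-methylpiperazin-1-yl gives a 2.1-fold lower number from compound 2 to compound 4 (0.33 log units; beyond the scatter), a modest step. The two groups have the same counts of hydrogen-bond donors and acceptors, so those counts do not separate compound 2 from compound 4. No measurement shown gives a cause for the step.

As far as these compounds go, it remains open how far the read-out depends on the ring type at this carbon. A morpholine or an open-chain dimethylamine there could help to separate ring type from other differences.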